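The source may report more compounds than this note shows. Statements on the series, on what has been measured and on what is new or still open speak of the compounds shown alone.

Measured compounds in an assay on isolated protein for inhibition of Dihydrofolate reductase (Homo sapiens), read by spectrophotometry; a lower number here means a stronger inhibitor, a higher number a weaker inhibitor:
Compound 1, `CCN(Cc1nc2cc(C(F)(F)F)ccc2nc1-c1ccccc1)c1ccc(OC)c(OC)c1`, gives 4000 nM.
Compound 2, `CCN(Cc1nc2cc(C(F)(F)F)ccc2nc1-c1ccccc1)c1cc(OC)c(OC)c(OC)c1`, gives 6000 nM.
Compound 3, `C#CCN(Cc1nc2cc(C(F)(F)F)ccc2nc1-c1ccccc1)c1ccc(OC)c(OC)c1`, gives 3000 nM.

Compound 4, `C#CCN(Cc1nc2cc(C(F)(F)F)ccc2nc1-c1ccccc1)c1cc(OC)c(OC)c(OC)c1`, has not been measured yet. It differs from compound 3 by methoxy in place of hydrogen on an aromatic carbon. The same change separates compound 1 from compound 2, (methoxy in place of hydrogen on an aromatic carbon), and there it made a 1.5-fold higher number from compound 1 to compound 2 (0.18 log units; within the scatter). The two cores differ by ethynyl in place of methyl on a saturated chain carbon bound to a nitrogen on an aromatic ring, a change that gave a 1.3-fold lower number from compound 1 to compound 3 (0.12 log units; within the scatter). As the surroundings of the changed position are described in identical words for both pairs, the change counts as the same one, and a step of like size is expected in this assay: the estimate is a 1.5-fold higher number from compound 3 to compound 4 (0.18 log units; within the scatter), resting on a 1.5-fold higher number from compound 1 to compound 2 (0.18 log units; within the scatter). Compound 4 is therefore expected to give 4500 nM, with a likely range from 2500 nM to 8000 nM.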

Compound 4, inhibition constant: 4000 nM
Estimate against measurement, compound 4: 1.1-fold (0.05 log units) above, within the range that was stated.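

In this assay, methoxy in place of hydrogen, turning 3,4-dimethoxyphenyl into 3,4,5-trimethoxyphenyl, reads as a 1.3-fold higher number from compound 3 to compound 4 (0.12 log units; within the scatter), and it agrees with the same change on the other core: the same change on two cores in this assay, a 1.5-fold higher number (0.18 log units; within the scatter) from compound 1 to compound 2 and a 1.3-fold higher number (0.12 log units; within the scatter) from compound 3 to compound 4, 1.1-fold (0.05 log units) apart, within the scatter of two such steps. Ethynyl in place of methyl on the chain reads as a 1.5-fold lower number from compound 2 to compound 4 (0.18 log units; within the scatter), and it also agrees with its earlier counterpart: the same change on two cores in this assay, a 1.3-fold lower number (0.12 log units; within the scatter) from compound 1 to compound 3 and a 1.5-fold lower number (0.18 log units; within the scatter) from compound 2 to compound 4, 1.1-fold (0.05 log units) apart, within the scatter of two such steps. Each change therefore carries across these two cores without a detectable difference, but every step lies within the scatter, so this does not show that either change truly alters inhibition or that a larger step would carry over in the same way.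

The compounds shown leave open what an amine or a carboxylic acid would do on that aromatic ring in place of methoxy. They also leave open whether a longer chain on the nitrogen would move the number beyond the scatter.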